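A few compounds are considered here, and "the series" means these few. Any claim that something is new, unique, unknown or untested is made for them only; others in the source may bear on it.

Measured compounds:
- compound 1, `O=C1CSc2ccc(NC(=O)C3CCN(c4cc(F)c(F)c(F)c4)CC3)cc2N1`, 1960 nM
- compound 2, `O=C1COc2ccc(NC(=O)C3CCN(c4ccccc4Br)CC3)cc2N1`, 160 nM
- compound 3, `O=C1COc2ccc(NC(=O)C3CCN(c4cccc(Cl)c4)CC3)cc2N1`, 190 nM

In a functional assay for antagonist activity at transient receptor potential cation channel subfamily V member 1 (Homo sapiens), read by FLIPR and calcium flux (on this read-out higher numbers stand for weaker inhibition and lower numbers for stronger inhibition), compound 3 stands second highest of the three numbers. Its nearest neighbour is compound 2, whose value of 160 nM lies within the scatter of it; the step of a 1.2-fold higher number from compound 2 to compound 3 (0.07 log units; within the scatter) is accordingly too small to read as a change. Compound 1, with 1960 nM, stands furthest from compound 3, beyond the scatter.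

The unmeasured compound 4, `O=C1COc2ccc(NC(=O)C3CCN(c4cccc(Br)c4)CC3)cc2N1`, differs from compound 3 in one place: bromo in place of chloro on an aromatic carbon. The change sits on an aromatic carbon of a six-membered aromatic ring of carbon only, meta to a large group, and cut one bond further out reads 3-chlorophenyl to 3-bromophenyl.

For the measured compounds named here, only one measured step bears on it, and only loosely: the step from compound 2 to compound 3 swaps a 2-bromophenyl for a 3-chlorophenyl and came out within the scatter. Going by the values given here, no step among the measured compounds exchanges chloro for bromo at the same place. With a halogen giving way to a halogen of the same kind at the same position, compound 4 is expected to stay close to compound 3, with the step of a 1.1-fold lower number from compound 3 to compound 4 (0.05 log units; within the scatter) expected to remain within the scatter. Compound 4 is therefore estimated at 170 nM in this assay, between 80 nM and 360 nM.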

Compound 4, half-maximal inhibitory concentration: 330 nM
Beside the measured number, compound 4's estimate is 1.9-fold (0.29 log units) below it; measured number inside the range.
By their numbers in this assay, from the lowest: compounds 2, 3 and 4 (each within the scatter of the next, the first and the last beyond it); then compound 1.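

In this assay the exchange of chloro for bromo on this aromatic carbon can now be read directly, and a 1.7-fold higher number from compound 3 to compound 4 (0.24 log units; within the scatter) shows that 3-chlorophenyl and 3-bromophenyl cannot be told apart at this position. For the compounds shown here, the same halogen can now also be compared in two places for the first time. This comparison gives a 2.1-fold higher number from compound 2 to compound 4 (0.31 log units; beyond the scatter), a modest step, and 3-bromophenyl and 2-bromophenyl do separate here, whereas the earlier comparison of 2-bromophenyl with 3-chlorophenyl did not. Nothing measured here explains either step.

Going by these compounds, whether a fluoro, methyl, methoxy or trifluoromethyl group on the same aromatic carbon would stay within the scatter of compound 3 remains open. Also open, on these data alone, is whether the small separation between the 2-bromophenyl and 3-bromophenyl compounds would recur with chloro in the same two places.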